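Extending the Chain from Propyl to Butyl

The compounds below may be only part of what the source reports. "The series", "measured", "known", "first", "only" and "open" are said of these compounds alone.

Growth inhibition measured in a functional assay on HeLa cells (Homo sapiens) for antiproliferative activity, read by sulforhodamine B assay; a higher number here means a weaker inhibitor of growth, a lower number a stronger inhibitor of growth:
- Compound 1 `O[C@H]1CO[C@H](COCc2ccccc2)[C@@H](OCc2ccccc2)[C@@H]1OCc1ccccc1`: > 50000 nM, a limit of the assay and not a number
- Compound 2 `CC[C@@H]1O[C@H](COCc2ccccc2)[C@@H](OCc2ccccc2)[C@H](OCc2ccccc2)[C@H]1O`: 19800 nM
- Compound 3 `CCC[C@@H]1O[C@H](COCc2ccccc2)[C@@H](OCc2ccccc2)[C@H](OCc2ccccc2)[C@H]1O`: 18900 nM

Only two of these results are numbers, and they lie within the scatter of each other: compound 2 gives 19800 nM and compound 3 gives 18900 nM in this assay. Compound 4 `CCCC[C@@H]1O[C@H](COCc2ccccc2)[C@@H](OCc2ccccc2)[C@H](OCc2ccccc2)[C@H]1O` differs from compound 3 by methyl in place of hydrogen on a saturated chain carbon, three bonds along the chain from a saturated ring carbon, which turns propyl into butyl.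

Going by the values given here, the closest precedent is the ethyl to propyl change, a 1.0-fold lower number from compound 2 to compound 3 (0.02 log units; within the scatter), which stays within the scatter. The larger steps, an at least 2.5-fold lower number from compound 1 to compound 2 (0.40 log units; beyond the scatter) and an at least 2.6-fold lower number from compound 1 to compound 3 (0.42 log units; beyond the scatter), start from a limit and place a whole chain on a ring carbon, so they bear less directly on this change. The expected step is a 1.2-fold lower number from compound 3 to compound 4 (0.07 log units; within the scatter), with no shift beyond the scatter anticipated. Compound 4 is estimated at 16000 nM, with an expected range from 8000 nM to 32000 nM.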

Compound 4, concentration for 50% growth inhibition: > 50000 nM
Compound 4: a limit, no number (the forecaster's own chance of this, stated with the estimate: 8%); middle value at least 3.1-fold (0.49 log units) away from the limit.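

In this assay compound 4 gives a limit of the assay and not a number, as does compound 1, so the step between these two cannot be read: the limit of > 50000 nM in this assay, at which 2 of the 4 values shown sit. The earlier compounds shown here suggested that chain length hardly mattered at this position, with a 1.0-fold lower number from compound 2 to compound 3 (0.02 log units; within the scatter), but butyl breaks that flat run, with an at least 2.6-fold higher number from compound 3 to compound 4 (0.42 log units; beyond the scatter) and an at least 2.5-fold higher number from compound 2 to compound 4 (0.40 log units; beyond the scatter). Adding methyl three bonds along the chain from a saturated ring carbon thus weakens growth inhibition, which the same addition two bonds along did not do.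

Going by these compounds, the limit of compound 4 gives no number, so the true size of the loss at butyl stays open. Also open, on these data alone, is whether a pentyl chain, or an amine carried on the butyl chain, would restore or further lower growth inhibition at this position.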